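This account rests on a few compounds, and the source may have more. Where it says the series, first, only, none or still open, it means among the compounds named here.

Measured so far:
compound 1 `O=C(CSc1nncnc1-c1ccccc1Cl)Nc1ccccc1Br`, 73000 nM;
compound 2 `Cc1ccc(NC(=O)CSc2nncnc2-c2ccccc2Cl)c(Br)c1`, 45000 nM;
compound 3 `Cc1ccccc1NC(=O)CSc1nncnc1-c1cccc2ccccc12`, 158000 nM.

In an ADME assay on MT4 cells (Homo sapiens) for cytotoxicity, read by MTT assay (on this read-out higher numbers stand for lower toxicity in this test and lower numbers for higher toxicity in this test), compound 3 gives the highest of the three numbers; compound 1 and compound 2 lie lower, both by steps beyond the scatter. How the core of compound 3 differs from that of compound 2 is not broken down here. Between compound 2 and compound 1 the change hydrogen in place of methyl on an aromatic carbon made a 1.6-fold higher number from compound 2 to compound 1 (0.21 log units; within the scatter).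

Compound 4 `O=C(CSc1nncnc1-c1cccc2ccccc12)Nc1ccccc1` is not yet measured. It arises from compound 3 by hydrogen in place of methyl on an aromatic carbon, the same kind of change, though the place differs: in compound 2 the methyl sits meta to a bromo group and para to a large group, in compound 3 ortho to a large group. Resting on the step from compound 2 to compound 1, the expected step of a 1.3-fold higher number from compound 3 to compound 4 (0.10 log units; within the scatter) is small. Compound 4 is thus estimated at 200000 nM in this assay.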

Compound 4, half-maximal cytotoxic concentration: 154000 nM
Beside the measured number, compound 4's estimate is 1.3-fold (0.11 log units) above it; the range from low to high includes it.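

In this assay, hydrogen in place of methyl on an aromatic carbon gives a 1.0-fold lower number from compound 3 to compound 4 (0.01 log units; within the scatter), so compound 3 and compound 4 cannot be told apart. Set beside the earlier case, the change reads alike on both cores: the same change on two cores in this assay, a 1.6-fold higher number (0.21 log units; within the scatter) from compound 2 to compound 1 and a 1.0-fold lower number (0.01 log units; within the scatter) from compound 3 to compound 4, 1.7-fold (0.22 log units) apart, within the scatter of two such steps. Within the data shown here, this shows that, on these two cores, the change leaves the number within the scatter, but it rests on only two pairs with the methyl in different places and shows nothing about other cores.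

The compounds shown leave open whether an ethyl or methoxy group in place of that methyl would move the number beyond the scatter. They also leave open how an amine or a carboxylic acid on that ring would read.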